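The compounds below may be only part of what the source reports. "The series", "measured", "known", "first", "only" and "open" are said of these compounds alone.

Compound 1 `CCCCCCOC[C@@H]1C2CCC(O2)[C@@H]1C/C=C\CCCC(=O)O` has been tested twice in a functional assay (plasma) for inhibition, with Homo sapiens as the target (a higher number here means a weaker inhibitor, a lower number a stronger inhibitor), giving 38500 nM; 10000 nM (2 entries); the two entries of compound 1, (the several entries of compound 1 in this assay, 38500 nM; 10000 nM (2 entries)), lie further apart than repeats of this kind usually do. Within the data shown here, compound 2 `O=C(O)CCC/C=C\CC1C2CCC(O2)C1COCC1CCCCC1` in this assay gives 165000 nM, the only number it has there; a further entry for compound 2 produced no single number. Among the measured compounds shown here, these are the only measured values in the set.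

Compound 3 `C=CCOCC1C2CCC(O2)C1C/C=C\CCCC(=O)O` differs from compound 2 by one change, (vinyl in place of cyclohexyl on a saturated chain carbon bound to an oxygen on a saturated carbon). Seen one bond further out, the ether arm of the shared core goes from cyclohexylmethoxy to allyloxy. For the measured compounds named here, no measured pair differs in just this way, so there is no measured step to lean on, and compound 1 carries a different arm altogether, so its values say nothing direct about this swap. The expectation is a step of a 1.2-fold higher number from compound 2 to compound 3 (0.08 log units; within the scatter) that stays within the usual scatter, in no settled direction. Compound 3 is therefore estimated at 200000 nM, with a range from 50000 nM to 800000 nM.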

Compound 3, half-maximal inhibitory concentration: 6000 nM
Beside the measured number, compound 3's estimate is 33-fold (1.52 log units) above it, and the stated range ends above it.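

The ether arm turns out to matter in this assay: vinyl in place of cyclohexyl on a saturated chain carbon bound to an oxygen on a saturated carbon gives a 28-fold lower number from compound 2 to compound 3 (1.44 log units; beyond the scatter) and so lies well beyond ordinary repeat noise. Until now, nothing showed whether this position responded to a change at all, whereas this pair shows that it does, with the smaller allyloxy arm, which has no ring, giving the stronger inhibitor of the two. This is still a single pair, and the repeat measurements of compound 1 are a reminder that individual numbers in this assay can spread more widely than is usual: the several entries of compound 1 in this assay, 38500 nM; 10000 nM (2 entries).

The swap removes the ring, shortens the arm and brings in a double bond all at once, and the compounds shown do not separate these three changes. They also leave open how a saturated propyl arm, a benzyl arm or an arm ending in an amine would read in this assay on the same core.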